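Notes on butyl in place of cyclopentyl

The source may report more compounds than this note shows. Statements on the series, on what has been measured and on what is new or still open speak of the compounds shown alone.

Measured so far in a functional assay on HeLa cells (Homo sapiens) for antiproliferative activity, read by CCK-8 assay, with a stated time of 72 h (on this read-out higher numbers stand for weaker inhibition and lower numbers for stronger inhibition), for this series:
- compound 1 `Nc1ccccc1NC(=O)c1ccc(Cn2cnc3c(NCc4ccccc4)nc(Cl)nc32)cc1` gives 6770 nM
- compound 2 `Nc1ccccc1NC(=O)c1ccc(COCNc2nc(Nc3ccccc3)c3ncn(C4CCCC4)c3n2)cc1` gives 8700 nM

Compound 2 at 8700 nM stands within the scatter of compound 1, so the two measured values cannot be ranked. Among the measured compounds shown here, no measured pair differs in one place only, so no single change has yet been sized.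

Compound 3 `CCCCn1cnc2c(Nc3ccccc3)nc(NCOCc3ccc(C(=O)Nc4ccccc4N)cc3)nc21` is still to be measured in this assay and carries butyl in place of cyclopentyl on an aromatic nitrogen, with butyl in place of cyclopentyl on an aromatic nitrogen as the counted difference. The place is on an aromatic nitrogen of a five-membered aromatic ring with 2 nitrogen, part of a fused or bridged system of two rings.

For the measured compounds named here, no measured step covers this place. The expectation therefore rests on compound 2 at 8700 nM alone, and no step beyond the scatter is expected in this assay for this change. The estimated 1.1-fold lower number from compound 2 to compound 3 (0.04 log units; within the scatter) is expected to stay small. Going by the values given here, the range is kept wide: only two measured values exist, and neither comes from a step at this place. For compound 3 the estimated value is 8000 nM with an expected range from 3500 nM to 18000 nM in this read-out.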

Compound 3, half-maximal inhibitory concentration: 3290 nM
Compound 3: the middle estimate sits 2.4-fold (0.39 log units) above what was measured, and the stated range ends above it.
By their numbers in this assay, from the lowest: compound 3; then compounds 1 and 2 (each within the scatter of the next).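

Butyl in place of cyclopentyl on an aromatic nitrogen gives a 2.6-fold lower number from compound 2 to compound 3 (0.42 log units; beyond the scatter) in this assay, the first step in this series between compounds that differ in one place only. This shows that the read-out responds to the group at this position, although the step is modest, and that in this pair a five-membered non-aromatic ring of carbon only is not needed there to keep the activity seen in compound 2. Nothing measured bears on why the number moves, and the opening of the ring cannot be separated from the change in heavy atoms.

From the compounds shown here alone, whether a longer chain such as hexyl, a branched chain such as isopropyl, or a butyl chain ending in an amine or a carboxylic acid would move the number further at this position remains open. Going by these compounds, the step also rests on a single pair, so it remains open whether the same change gives a step of similar size when other parts of the shared core carry different groups.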